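Aniline substituent change in the glutarimide series

The compounds below may be only part of what the source reports. "The series", "measured", "known", "first", "only" and "open" are said of these compounds alone.

Compound 1 `COc1ccc(Nc2ccc3c(c2)C(=O)N(C2CCC(=O)NC2=O)C3=O)cc1` gives 29% in an assay on FRT-Jurkat cells for inhibition of nuclear factor NF-kappa-B complex (Homo sapiens), read by flow cytometry, with a stated time of 24 h, tested at 10 uM; on this read-out higher numbers stand for more inhibition at the one concentration tested (going by the name of the read-out) and lower numbers for less inhibition. Among the measured compounds shown here, compound 2 `CCOC(=O)c1ccc(Nc2ccc3c(c2)C(=O)N(C2CCC(=O)NC2=O)C3=O)cc1` gives 5% in this assay, which is the lower of the two numbers seen so far; the only measured step, a number 24 percentage points lower from compound 1 to compound 2 (beyond the scatter), goes from the higher number of compound 1 down to compound 2. Compound 3 `CC(C)(C)c1ccc(Nc2ccc3c(c2)C(=O)N(C2CCC(=O)NC2=O)C3=O)cc1` is not yet measured; it differs from compound 2 by tert-butyl in place of ethoxycarbonyl on an aromatic carbon. For the measured compounds named here, the step bearing on this change is the one from compound 1 to compound 2, where replacing methoxy by ethoxycarbonyl at the same aromatic carbon lowered the read-out modestly. Tert-butyl is neither of those groups, so no step covers it directly. Since removal of ethoxycarbonyl reverses the group that accompanied the drop in a number 24 percentage points lower from compound 1 to compound 2 (beyond the scatter), a modest rise is expected, a number 15 percentage points higher from compound 2 to compound 3 (beyond the scatter), with wide uncertainty. Compound 3 is estimated at 20%, in the range 0% to 45%.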

Compound 3, a percentage reported as inhibition, at one concentration (the size of the read-out at that concentration, not a potency): 17%
Compound 3: the middle estimate sits 3 percentage points above what was measured; the measured number falls inside the stated range.
By their numbers in this assay, from the lowest: compound 2; then compound 3; then compound 1.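

Tert-butyl in place of ethoxycarbonyl gives a number 12 percentage points higher from compound 2 to compound 3 (beyond the scatter) in this assay and tert-butyl in place of methoxy gives a number 12 percentage points lower from compound 1 to compound 3 (beyond the scatter) on the same read-out. The group with only carbon therefore falls between the two groups that contain oxygen, so the presence of oxygen at this aromatic carbon does not sort the three numbers. Removing ethoxycarbonyl recovers part of the gap to compound 1, but tert-butyl does not close it. Nothing measured here explains this order.

Open, going by these compounds, is how an amine or a carboxylic acid at this carbon would compare with these three groups. Also open, on these data alone, is whether a longer chain in place of the tert-butyl would move the number in either direction.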